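The compounds below may be only part of what the source reports. "The series", "measured", "known", "first", "only" and "open" are said of these compounds alone.

Compound 1 `CC(C)CC(=O)N1CCc2cc(CNC(=O)c3ccco3)ccc21`: 100%
Compound 2 `CC(C)CC(=O)N1CCc2cc(CNC(=O)C3CC3)ccc21`: 35%

In an assay on HEK293 cells for inhibition of Indoleamine 2,3-dioxygenase 1 (Homo sapiens), tested at 10 uM (on this read-out higher numbers stand for more inhibition at the one concentration tested (going by the name of the read-out) and lower numbers for less inhibition), compound 2 gives the lower of the two numbers, with compound 1 above it by the step of a number 65 percentage points lower from compound 1 to compound 2 (beyond the scatter). Compound 3 `CC(C)CC(=O)N1CCc2cc(CNC(=O)c3cccnc3)ccc21` differs from compound 2 in one place: pyridin-3-yl in place of cyclopropyl on a carbonyl carbon. Among the measured compounds shown here, the only measured step that bears on this swap is the one from compound 1 to compound 2, where an aromatic ring gave way to cyclopropyl and inhibition fell by a large amount. Returning to an aromatic ring on the carbonyl carbon is therefore expected to raise inhibition again, by roughly a number 45 percentage points higher from compound 2 to compound 3 (beyond the scatter). Compound 3 is expected to give about 80%, within a range from 50% to 100%.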

Compound 3, a percentage reported as inhibition, at one concentration (the size of the read-out at that concentration, not a potency): 86%
For compound 3 the middle estimate is 6 percentage points below the measured one; the measured number falls inside the stated range.
By their numbers in this assay, from the lowest: compound 2; then compound 3; then compound 1.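

Pyridin-3-yl on the carbonyl carbon recovers most of the inhibition lost with cyclopropyl (a number 51 percentage points higher from compound 2 to compound 3 (beyond the scatter)), so the high number is not unique to furan-2-yl: a second aromatic ring, this one six-membered and containing nitrogen, also gives a much higher number than cyclopropyl. The two aromatic rings are still not interchangeable (a number 14 percentage points lower from compound 1 to compound 3 (beyond the scatter)), so the choice of ring matters at this position. No measurement here explains either step. On these data alone, it remains open whether phenyl, an aromatic ring of carbon only, would match pyridin-3-yl. As far as these compounds go, it also remains open whether a larger non-aromatic ring such as cyclohexyl would stay as low as cyclopropyl.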